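The source may report more compounds than this note shows. Statements on the series, on what has been measured and on what is new or still open speak of the compounds shown alone.

In a physicochemical assay for lipophilicity (a lower number here means a more polar compound, a higher number a more lipophilic compound), compound 2 `Cc1nc(-c2cc(C(F)(F)F)ccc2[C@H]2CCOc3cc(S(=O)(=O)Nc4ncc(F)cn4)ccc32)co1` gives 2.8. Compound 3 `Cc1ccc(-c2cc(C(F)(F)F)ccc2[C@H]2CCOc3cc(S(=O)(=O)Nc4ncc(F)cn4)ccc32)cn1` gives 2.5, which lies within the scatter of that figure. Compound 1 `O=S(=O)(Nc1nccs1)c1ccc2c(c1)OCC[C@H]2c1ccc(C(F)(F)F)cc1-n1ccnn1` gives 2.3, which lies lower than the figure for compound 2 by more than the scatter.

The next compound to be measured is compound 4 `Cc1nc(-c2cc(C(F)(F)F)ccc2[C@H]2CCOc3cc(S(=O)(=O)Nc4nccs4)ccc32)co1`. It keeps the 2-methyl-1,3-oxazol-4-yl group of compound 2 and exchanges one other group: 1,3-thiazol-2-yl in place of 5-fluoropyrimidin-2-yl on a sulfonamide nitrogen. In words, 1,3-thiazol-2-yl stands in place of 5-fluoropyrimidin-2-yl on a sulfonamide nitrogen.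

Going by the values given here, no measured step covers this exchange. Among the compounds with values here, the one measured step, a number 0.30 log units lower from compound 2 to compound 3 (within the scatter), concerns a different group on an aromatic carbon, so it offers only a rough sense of how far such compounds can move. Compound 1 carries the same 1,3-thiazol-2-yl on its sulfonamide nitrogen, but it also differs from compound 2 in a second group, so the gap between their values cannot be assigned to this exchange alone.

With no evidence for a direction, no step beyond the scatter is expected in this assay. The estimated step is no change at the digits printed from compound 2 to compound 4 (within the scatter). The expected value for compound 4 is 2.8. The expected range for compound 4 runs from 2.4 to 3.2.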

Compound 4, distribution coefficient: 2.9
Estimate against measurement, compound 4: 0.10 log units below; measured number inside the range.
By their numbers in this assay, from the lowest: compounds 1, 3, 2 and 4 (each within the scatter of the next, the first and the last beyond it).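

In this assay the sulfonamide nitrogen now has its first exchange that can be read on its own: with the 2-methyl-1,3-oxazol-4-yl group held fixed, 1,3-thiazol-2-yl in place of 5-fluoropyrimidin-2-yl gives a number 0.10 log units higher from compound 2 to compound 4 (within the scatter) as its step. The earlier compounds shown here could not show this, since compound 1 carries the same 1,3-thiazol-2-yl but differs from compound 2 in a second group as well. Here a five-membered aromatic ring enters for a six-membered one, and the two groups, different in size and in their hetero atoms, still read alike within the scatter, though nothing measured here bears on why that is so.

The compounds shown leave open whether the same exchange would read the same way with another group on the aromatic carbon, such as the 6-methylpyridin-3-yl of compound 3. They also leave open how the number would respond to a group of a different kind on the sulfonamide nitrogen, such as a plain phenyl ring or a short chain ending in a carboxylic acid.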